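This account rests on a few compounds, and the source may have more. Where it says the series, first, only, none or still open, it means among the compounds named here.

Working notes on the series. In an ADME assay on the whole organism (strain Sprague-Dawley) for pharmacokinetics, with Rattus norvegicus as the target, read by LC-MS, at a dose of 2 mg/kg by the oral route (a higher number here means that a larger share of the oral dose reaches the circulation, a lower number that a smaller share of the oral dose reaches the circulation), compound 1 `Cn1c(-c2cccnc2)nc2ccc(F)cc21` gives 37% and compound 2 `Fc1cc2nc(-c3cccnc3)n(C3CC3)c2cc1F` gives 92%. Within the data shown here, compound 2 therefore holds the higher of the only two numbers available, and the gap between the two lies beyond the scatter.

The next compound to be read is compound 3 `Fc1ccc2nc(-c3cccnc3)n(C3CC3)c2c1`. Relative to compound 2, the change is hydrogen in place of fluoro on an aromatic carbon. Among the measured compounds shown here, no measured pair shows this change on its own, so the data give no direct precedent for its size.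

Because compound 2 already stands at 92%, little room remains upward, and a downward move is the more likely outcome. A moderate drop beyond the scatter is expected, although a result within the scatter of compound 2 cannot be ruled out. The estimated move is a number 20 percentage points lower from compound 2 to compound 3 (beyond the scatter). The value of compound 1, 37%, serves as a rough guide to the lower end. For compound 3 the expected value is 72%, with an estimated range of 42% to 95%.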

Compound 3, oral bioavailability: 77%
For compound 3 the middle estimate is 5 percentage points below the measured one; the measured number falls inside the stated range.
By their numbers in this assay, from the lowest: compound 1; then compound 3; then compound 2.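

Compound 3 separates the two structural differences between compound 1 and compound 2 into single changes that can be read on their own. At this position, on the aromatic carbon ortho to the remaining fluoro group, hydrogen in place of fluoro gives a number 15 percentage points lower from compound 2 to compound 3 (beyond the scatter) in this assay, a modest step but one that is still beyond the scatter, so this fluoro group does register in the read-out on the cyclopropyl-bearing core. Cyclopropyl in place of methyl on the aromatic nitrogen gives a number 40 percentage points higher from compound 1 to compound 3 (beyond the scatter) in this assay, a large step, and nothing available accounts for the size of either step.

Going by these compounds, the fluoro step is read only with cyclopropyl on the aromatic nitrogen, and the cyclopropyl step only with hydrogen at this position, so it remains open whether either would keep its size with the other group changed. On these data alone, it is also open how chloro or methoxy on this aromatic carbon, or a longer chain or an amine in place of cyclopropyl on the aromatic nitrogen, would read in this assay.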